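The compounds below may be only part of what the source reports. "The series", "measured", "known", "first", "only" and "open" are said of these compounds alone.

Compound 1, `COC(=O)c1sc2cc(C#Cc3ccc(OC)cc3)cnc2c1N`: > 37500 nM, a limit of the assay
Compound 2, `COC(=O)c1sc2cc(C#Cc3ccccc3OC)cnc2c1N`: > 47300 nM, a limit of the assay

Both measured values are limits of the assay and not numbers. In a functional assay on A375-C5 cells (Homo sapiens) for inhibition, read by sulforhodamine B assay, with a stated time of 48 h (on this read-out higher numbers stand for weaker inhibition of growth and lower numbers for stronger inhibition of growth), compound 1 reaches only the limit > 37500 nM. Compound 2 likewise reaches only the limit > 47300 nM. Compound 1 therefore stands at a limit, with no number of its own. Among the compounds with values here, the single measured step, a step that the two limits leave unreadable from compound 1 to compound 2, cannot be read in size because the limit of > 37500 nM in this assay, at which 1 of the 2 values shown sits, and the limit of > 47300 nM in this assay, at which 1 of the 2 values shown sits, are both limits.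

Compound 3, `COC(=O)c1sc2cc(C#Cc3ccc(N(C)C)cc3)cnc2c1N`, has not yet been measured. It differs from compound 1 by dimethylamino in place of methoxy on an aromatic carbon. Within the data shown here, only the step from compound 1 to compound 2 could bear on this change, and since it is unreadable, it gives no size to expect in this assay, neither a direction nor a step beyond the scatter. Compound 3 is therefore expected to sit near 40000 nM, within about 5000 nM to 100000 nM, and most likely as a limit again. The step this estimate means, a step that the limit leaves unreadable from compound 1 to compound 3, is an expectation only.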

Compound 3, concentration for 50% growth inhibition: 17700 nM
Compound 3: the middle estimate sits 2.3-fold (0.35 log units) above what was measured, and the stated range covers the measured number.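

Dimethylamino in place of methoxy, on an aromatic carbon para to a large group, gives the first readable step in this assay: it is an at least 2.1-fold lower number from compound 1 to compound 3 (0.32 log units; beyond the scatter) and so points to stronger inhibition of growth. Within the data shown here, the earlier step between the two methoxy compounds cannot be read, so this is the first sign that the group on this carbon can change the result by more than the usual scatter. The printed size is only a minimum, and the real gap could be wider, because compound 1 holds a limit of the assay and not a number: the limit of > 37500 nM in this assay, at which 1 of the 3 values shown sits.

One exchange at one position cannot show which feature of dimethylamino goes with the lower number, or whether any other nitrogen group on this carbon would behave the same way. A plain amine, a diethylamino group or a morpholine ring at this place would test how far the step extends, and a carboxylic acid there would test whether a quite different group also moves the number, but the compounds shown say nothing about any of these.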